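Phenyl for propargyl on the ring nitrogen of compound 2

The compounds below may be only part of what the source reports. "The series", "measured", "known", "first", "only" and "open" are said of these compounds alone.

Of the compounds shown here, two have been measured in an assay on isolated protein for displacement of a labelled ligand from galanin receptor type 3 (Homo sapiens); a higher number here means a weaker inhibitor, a lower number a stronger inhibitor. Compound 2 (`C#CCN1C(=O)/C(=N/c2cccc(C(F)(F)F)c2)c2ccccc21`) gives 89 nM in this assay, and compound 1 (`C=CCN1C(=O)/C(=N/c2ccc(Cl)c(Cl)c2)c2ccccc21`) gives 150 nM. The two numbers lie within the usual scatter of each other, so compound 2 stands beside compound 1 rather than apart from it. Compound 3 (`O=C1/C(=N/c2cccc(C(F)(F)F)c2)c2ccccc2N1c1ccccc1`) is not yet measured; it differs from compound 2 in one place: phenyl in place of propargyl on an amide-type nitrogen in a ring. Going by the values given here, no measured pair shows this kind of change, so there is nothing to say which way it should move the number or by how much. A step no larger than the scatter, in either direction, is expected. Compound 3 is therefore expected to give about 110 nM, between 30 nM and 400 nM. That estimate means a step of a 1.2-fold higher number from compound 2 to compound 3 (0.09 log units; within the scatter) that is expected to stay within the scatter.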

Compound 3, inhibition constant: 17 nM
For compound 3 the middle estimate is 6.5-fold (0.81 log units) above the measured one; measured number below the stated range.
By their numbers in this assay, from the lowest: compound 3; then compounds 2 and 1 (each within the scatter of the next).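

In this assay, going by these compounds alone, the step to phenyl gives a 5.2-fold lower number from compound 2 to compound 3 (0.72 log units; beyond the scatter), so the amide-type nitrogen in the ring is a place where the group matters, which the earlier compounds could not show. It also shows that this place accepts a six-membered aromatic ring of carbon only, with 6 heavy atoms where propargyl has 3, and that the number falls rather than rises with this change. Nothing measured here explains why the number moves in this direction.

The compounds shown leave open whether the gain belongs to the aromatic ring itself or would also come with a saturated ring such as cyclohexyl, or with benzyl. They also leave open how a phenyl carrying a methoxy group or an amine would behave, and whether the same change would give a similar step on compound 1.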